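Replacing the Methoxycyclohexyl Tail with a Pentyl Chain

The compounds below may be only part of what the source reports. "The series", "measured", "known", "first", "only" and "open" are said of these compounds alone.

Compound 1 `COc1ccccc1C(=O)Nc1c[nH]nc1C(=O)N[C@H]1CC[C@H](OC)CC1` gives 1500 nM in an ADME assay on MRC5 cells (Homo sapiens) for inhibition, with a stated time of 72 h; a lower number here means that less compound is needed, a higher number that more compound is needed for the effect.
Compound 2 `COc1cccc(OC)c1C(=O)Nc1c[nH]nc1C(=O)N[C@H]1CC[C@H](O)CC1` gives 34000 nM.
Compound 3 `COc1cccc(OC)c1C(=O)Nc1c[nH]nc1C(=O)N[C@H]1CC[C@H](OC)CC1` gives 31000 nM.

Compound 3 has the second highest of the three numbers. It sits close to compound 2, the step of a 1.1-fold lower number from compound 2 to compound 3 (0.04 log units; within the scatter) lying within the scatter, while the step of a 21-fold higher number from compound 1 to compound 3 (1.32 log units; beyond the scatter) sets it far from compound 1. Compound 4 `CCCCCNC(=O)c1n[nH]cc1NC(=O)c1c(OC)cccc1OC` differs from compound 3 by pentyl in place of 4-methoxycyclohexyl on an amide-type nitrogen. Among the compounds with values here, no measured step changes this part of the molecule in the same way. Within the data shown here, the only step touching the same group, a 1.1-fold lower number from compound 2 to compound 3 (0.04 log units; within the scatter), was within the scatter, so a change here is expected to leave the number roughly where it is, perhaps somewhat higher. Compound 4 is therefore estimated at 40000 nM, within 12000 nM to 130000 nM, a step of a 1.3-fold higher number from compound 3 to compound 4 (0.11 log units; within the scatter).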

Compound 4, half-maximal effective concentration: > 50000 nM
Compound 4 was reported as a limit; the forecaster's own chance of this, stated with the estimate: 25%; at least 1.2-fold (0.09 log units) between middle value and limit.
By their numbers in this assay, from the lowest: compound 1; then compounds 3 and 2 (each within the scatter of the next). At a limit, above all of these: compound 4.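

Compound 4 gives a limit in this assay, not a number: the limit of > 50000 nM in this assay, at which 1 of the 4 values shown sits. The steps of an at least 1.6-fold higher number from compound 3 to compound 4 (0.20 log units; that floor lies within the scatter) and an at least 1.4-fold higher number from compound 2 to compound 4 (0.16 log units; that floor lies within the scatter) have floors within the scatter, so their true size cannot be read, but neither brings the number down. Compounds 2 and 3 differ only at the far end of the cyclohexyl group, whereas compound 4 shows that losing the whole ring for a pentyl chain on the amide-type nitrogen also brings no fall.

As far as these compounds go, how an amine or a carboxylic acid on that chain would read stays open. So does whether pentyl would behave alike on the core of compound 1.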